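This account rests on a few compounds, and the source may have more. Where it says the series, first, only, none or still open, it means among the compounds named here.

Three compounds share one core and differ only in the group attached to the saturated chain carbon bound to the carbonyl carbon. Compound 1 `C[C@@H]1CN(c2sc(C(F)(F)F)nc2-c2nc3ccccc3[nH]2)CCN1C(=O)Cn1cccn1` carries a 1H-pyrazol-1-yl there and in a functional assay on CHO-K1 cells for antagonist activity at C-X-C chemokine receptor type 3 (Homo sapiens), read by FLIPR, with a stated time of 10 min, in the presence of a further agent that is not named here (on this read-out lower numbers stand for stronger inhibition and higher numbers for weaker inhibition), compound 1 gives 13 nM. Compound 2 `C[C@@H]1CN(c2sc(C(F)(F)F)nc2-c2nc3ccccc3[nH]2)CCN1C(=O)CN1CCC(F)(F)CC1` carries a 4,4-difluoropiperidin-1-yl instead, and in this assay compound 2 gives 15 nM; the step of a 1.2-fold higher number from compound 1 to compound 2 (0.06 log units; within the scatter) lies within the scatter. Compound 3 `C[C@@H]1CN(c2sc(C(F)(F)F)nc2-c2nc3ccccc3[nH]2)CCN1C(=O)Cn1cc(Cl)cn1` carries a 4-chloro-1H-pyrazol-1-yl, and in this assay compound 3 gives 1.7 nM, the lowest number of the three: the step of a 7.6-fold lower number from compound 1 to compound 3 (0.88 log units; beyond the scatter) and the step of an 8.8-fold lower number from compound 2 to compound 3 (0.95 log units; beyond the scatter) both lie beyond the scatter.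

Compound 4 `C[C@@H]1CN(c2sc(C(F)(F)F)nc2-c2nc3ccccc3[nH]2)CCN1C(=O)Cn1cc(C2CCN(C)CC2)cn1` is not yet measured. It differs from compound 3 by 1-methylpiperidin-4-yl in place of chloro on an aromatic carbon. Among the compounds with values here, two measured steps bear on this. The step of a 7.6-fold lower number from compound 1 to compound 3 (0.88 log units; beyond the scatter) shows that putting chloro on that aromatic carbon lowered the number, and the step of an 8.8-fold lower number from compound 2 to compound 3 (0.95 log units; beyond the scatter) shows how far exchanging the whole group on the chain carbon can move it. Within the data shown here, no measured compound carries anything larger than chloro at that ring carbon, so the 1-methylpiperidin-4-yl has no direct precedent. Compound 4 is expected to keep part of the gain seen for compound 3 while giving some of it back, so the expected step is a 2.9-fold higher number from compound 3 to compound 4 (0.47 log units; beyond the scatter). The estimate for compound 4 in this assay is 5 nM, within a range from 1.5 nM to 20 nM.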

Compound 4, half-maximal inhibitory concentration: 15 nM
Compound 4: the middle estimate sits 3.0-fold (0.48 log units) below what was measured; low and high end bracket the measured number.
By their numbers in this assay, from the lowest: compound 3; then compounds 1, 2 and 4 (each within the scatter of the next).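

This result shows that the ring carbon in question, two ring bonds from the ring nitrogen, accepts a group much larger than chloro and still gives a measurable effect in this assay, but the gain from chloro does not carry over to the larger group: replacing chloro with 1-methylpiperidin-4-yl gives an 8.8-fold higher number from compound 3 to compound 4 (0.95 log units; beyond the scatter). Measured against plain hydrogen at the same carbon, the 1-methylpiperidin-4-yl gives a 1.2-fold higher number from compound 1 to compound 4 (0.06 log units; within the scatter), so adding this whole ring and its nitrogen leaves the number within the scatter, and the low number of compound 3 is so far tied to chloro alone. On the saturated chain carbon bound to the carbonyl carbon, the full 4-(1-methylpiperidin-4-yl)-1H-pyrazol-1-yl group shows no change at the digits printed from compound 2 to compound 4 (within the scatter), so this much larger group cannot be told apart from 4,4-difluoropiperidin-1-yl in this read-out.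

Nothing available here explains why chloro lowers the number while the 1-methylpiperidin-4-yl does not. From the compounds shown here alone, it remains open whether bromo, a methyl or a piperidin-4-yl without its methyl at this ring carbon would come close to compound 3 at 1.7 nM.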